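Trading a Hydroxymethyl for a Cyano on a Bridged Core

A few compounds are considered here, and "the series" means these few. Any claim that something is new, unique, unknown or untested is made for them only; others in the source may bear on it.

Three compounds share one saturated, bridged carbon core and differ only in the group attached to it. Compound 1 `BrC12CCCC3CC(CCC31)C2` carries a bromine there; in an ADME assay (Gallus gallus) for cytotoxicity, read by microscopy, with a stated time of 24 h (on this read-out lower numbers stand for higher toxicity in this test and higher numbers for lower toxicity in this test), compound 1 gives no result reported. Compound 2 `OCC12CCCC3CC(CCC31)C2` carries a hydroxymethyl group instead, and in this assay compound 2 gives 870000 nM. Within the data shown here, that is the only number reported, so compound 2 stands alone: there is no second measured compound to rank it against, and no measured step between two compounds to show how large a change of this kind tends to be.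

Compound 3 `N#CC12CCCC3CC(CCC31)C2` is the compound still to be measured. Its difference from compound 2 is cyano in place of hydroxymethyl on a saturated ring carbon. Among the measured compounds shown here, with no measured step available, the data point to no shift in either direction beyond the scatter. For the measured compounds named here, the only anchor is compound 2 with its 870000 nM. Compound 3 is therefore expected to give about 750000 nM, with a range from 300000 nM to 1800000 nM. The step of a 1.2-fold lower number from compound 2 to compound 3 (0.06 log units; within the scatter) that this estimate implies is expected to stay within the usual scatter.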

Compound 3, minimum cytotoxic concentration: 850000 nM
Beside the measured number, compound 3's estimate is 1.1-fold (0.05 log units) below it; the range from low to high includes it.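

In this assay, among these compounds, putting cyano in place of hydroxymethyl on a saturated ring carbon gives a 1.0-fold lower number from compound 2 to compound 3 (0.01 log units; within the scatter) and so offers the first measured step: the two compounds read alike. The swap keeps the count of 2 heavy atoms and 1 hydrogen-bond acceptor, while hydroxymethyl has 1 hydrogen-bond donor and cyano has 0 hydrogen-bond donors, so in this one pair, losing that donor comes with no difference beyond the usual scatter. No supporting measurement is available to explain why the two compounds read alike.

From the compounds shown here alone, whether an amine, a carboxylic acid or a longer chain on this same ring carbon would also leave the minimum cytotoxic concentration within the scatter remains open, as a single step cannot establish a pattern for this position. Going by these compounds, the place of bromine in this comparison also stays open: compound 1 gives no result reported in this assay and so offers no number to set beside the other two compounds.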